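Acetylation of the ring amine in the shared core

A few compounds are considered here, and "the series" means these few. Any claim that something is new, unique, unknown or untested is made for them only; others in the source may bear on it.

Measured compounds:
compound 1 `Cn1nc(N)c2c(=O)[nH]c(-c3ccccc3)cc21` gives 14% in an assay on isolated protein for inhibition of serine/threonine-protein kinase D2 (Homo sapiens), read by mobility shift assay, tested at 30 uM; on this read-out lower numbers stand for less inhibition and higher numbers for more inhibition at the one concentration tested (going by the name of the read-out)
compound 2 `COc1ccc(-c2cc3c(c(N)nn3C)c(=O)[nH]2)cc1` gives 36% in this assay
compound 3 `COc1cccc(-c2cc3c(c(N)nn3C)c(=O)[nH]2)c1` gives 25% in this assay

Compound 1 stands lowest of the three numbers in this assay. Its nearest neighbour is compound 3, with the step of a number 11 percentage points higher from compound 1 to compound 3 (beyond the scatter), and the furthest is compound 2, with the step of a number 22 percentage points higher from compound 1 to compound 2 (beyond the scatter). Both steps are beyond the scatter and both come from a methoxy in place of hydrogen on an aromatic carbon.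

Compound 4 `CC(=O)Nc1nn(C)c2cc(-c3ccccc3)[nH]c(=O)c12` is not yet measured. It differs from compound 1 as follows: acetyl in place of hydrogen on a nitrogen on an aromatic ring. The change sits on the nitrogen on the aromatic ring of the core, not on the phenyl substituent that the two measured steps alter. For the measured compounds named here, neither measured step therefore bears on this change; no step on this nitrogen has been measured. With nothing to support a shift in either direction, the expectation for compound 4 is a number close to that of compound 1, and the expected step is a number 2 percentage points lower from compound 1 to compound 4 (within the scatter), within the scatter. Compound 4 is therefore estimated at 12%, with a range from 0% to 28%.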

Compound 4, a percentage reported as inhibition, at one concentration (the size of the read-out at that concentration, not a potency): 9%
For compound 4 the middle estimate is 3 percentage points above the measured one; the range from low to high includes it.
By their numbers in this assay, from the lowest: compounds 4 and 1 (each within the scatter of the next); then compound 3; then compound 2.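

For the compounds shown here, replacing hydrogen with acetyl on the nitrogen on the aromatic ring gives the first measured step at this position of the shared core: in this assay, a number 5 percentage points lower from compound 1 to compound 4 (within the scatter). Unlike the two methoxy steps on the phenyl substituent, which lie beyond the scatter, amino to acetamido leaves compound 1 and compound 4 indistinguishable on this read-out, so this single change neither raises nor lowers the number measurably. No supporting evidence bears on this result.

From the compounds shown here alone, it remains open whether a larger acyl group, such as benzoyl, or a basic group such as a dimethylaminoacetyl chain on this nitrogen would separate from compound 1. Going by these compounds, it is equally open whether acetyl would give a similar result on the methoxyphenyl core of compound 2, where the starting number is higher.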